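Ring-size and methyl pairs in a thiosemicarbazone series

This account rests on a few compounds, and the source may have more. Where it says the series, first, only, none or still open, it means among the compounds named here.

Measured so far in a functional assay on MCF7 cells (Homo sapiens) for cytotoxicity, read by MTT assay, with a stated time of 72 h, tested at 100 uM; on this read-out higher numbers stand for more inhibition of growth at the one concentration tested and lower numbers for less inhibition of growth:
- compound 1 `N/C(=N\NC(=S)N1CCCCCC1)c1ccccn1` gives 84%
- compound 2 `Cc1cccc(/C(N)=N/NC(=S)N2CCCCCC2)n1` gives 70.2%
- compound 3 `Cc1cccc(/C(N)=N/NC(=S)N2CCCC2)n1` gives 61.8%

Compound 3 has the lowest of the three numbers, but its gap to compound 2 is within the scatter; only against compound 1 is it beyond the scatter. The difference between the core of compound 3 and the core of compound 2 is not broken down here. Compound 1 differs from compound 2 by hydrogen in place of methyl on an aromatic carbon, and the measured step is a number 13.8 percentage points higher from compound 2 to compound 1 (beyond the scatter).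

Compound 4 `N/C(=N\NC(=S)N1CCCC1)c1ccccn1` is not yet measured. It differs from compound 3 by hydrogen in place of methyl on an aromatic carbon, the same change as from compound 2 to compound 1, in the same place. Among the compounds with values here, it is expected that the step in this assay is a number 13.2 percentage points higher from compound 3 to compound 4 (beyond the scatter), resting on the one measured step of a number 13.8 percentage points higher from compound 2 to compound 1 (beyond the scatter). Compound 4 is therefore estimated at 75%, between 62% and 88%.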

Compound 4, percent growth inhibition at one concentration: 74.9%
The estimate for compound 4 lay 0.1 percentage points above the measured number; measured number inside the range.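

In this assay, hydrogen in place of methyl on an aromatic carbon gives a number 13.1 percentage points higher from compound 3 to compound 4 (beyond the scatter). Set beside the earlier step, the change carries over from one core to the other: the same change on two cores in this assay, a number 13.8 percentage points higher (beyond the scatter) from compound 2 to compound 1 and a number 13.1 percentage points higher (beyond the scatter) from compound 3 to compound 4, 0.7 percentage points apart, within the scatter of two such steps

This holds for these two cores only, at the one concentration tested; it does not show that the step would keep its size on any other core, and it gives no reason for the step.

The compounds shown carry only methyl or hydrogen at this place, so the effect of ethyl, chloro or methoxy there stays open. Also open, on these data alone, is whether a carbonyl in place of the thiocarbonyl would leave the step unchanged.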